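Trimming the Alkyl Chain: From Compound 3 to Compound 4

The source may report more compounds than this note shows. Statements on the series, on what has been measured and on what is new or still open speak of the compounds shown alone.

Measured so far in an assay on isolated protein for inhibition of acyl-CoA:cholesterol acyltransferase (Oryctolagus cuniculus); a lower number here means a stronger inhibitor, a higher number a weaker inhibitor:
- compound 1, `CCCCCCCCCCCCCCc1ccc(NC(=O)Nc2c(C(C)C)cccc2C(C)C)cc1`, gives 500 nM
- compound 2, `CCCCCCCc1ccc(NC(=O)Nc2c(C(C)C)cccc2C(C)C)cc1`, gives 19 nM
- compound 3, `CCCCCCCCCCCCc1ccc(NC(=O)Nc2c(C(C)C)cccc2C(C)C)cc1`, gives 15 nM

Compound 3 has the lowest number of the three in this assay. Its nearest neighbour is compound 2, and the step of a 1.3-fold lower number from compound 2 to compound 3 (0.10 log units; within the scatter) lies within the scatter, so the two cannot be ranked. Compound 1 stands far apart: a 33-fold lower number from compound 1 to compound 3 (1.52 log units; beyond the scatter) and a 26-fold lower number from compound 1 to compound 2 (1.42 log units; beyond the scatter) are both large.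

The next compound, compound 4, `CCCCCCCCCc1ccc(NC(=O)Nc2c(C(C)C)cccc2C(C)C)cc1`, differs from compound 3 by hydrogen in place of propyl on a saturated chain carbon, nine bonds along the chain from an aromatic carbon. Two of the measured steps bear on this. The step of a 1.3-fold lower number from compound 2 to compound 3 (0.10 log units; within the scatter) shows that adding pentyl to the chain of compound 2 changes nothing beyond the scatter, and compound 4 falls between compound 2 and compound 3, since removing propyl from compound 3 does not reach the chain of compound 2. The large step of a 33-fold lower number from compound 1 to compound 3 (1.52 log units; beyond the scatter) concerns a chain that is already longer than that of compound 3, so it is not expected to carry over here.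

The expected step of a 1.1-fold higher number from compound 3 to compound 4 (0.05 log units; within the scatter) is therefore small, within the scatter. Compound 4 is estimated at 17 nM, in the range 8 nM to 40 nM.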

Compound 4, half-maximal inhibitory concentration: 9 nM
Compound 4: middle estimate off by 1.9-fold (0.28 log units), on the high side; measured number inside the range.
By their numbers in this assay, from the lowest: compounds 4, 3 and 2 (each within the scatter of the next, the first and the last beyond it); then compound 1.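

In this assay, hydrogen in place of propyl at this position gives a 1.7-fold lower number from compound 3 to compound 4 (0.22 log units; within the scatter), so the two cannot be ranked, whereas ethyl in place of hydrogen on the shortest chain shown gives a 2.1-fold lower number from compound 2 to compound 4 (0.32 log units; beyond the scatter), a modest step and the first beyond the scatter among the three shorter chains. Hydrogen in place of pentyl at this same position gives a 56-fold lower number from compound 1 to compound 4 (1.74 log units; beyond the scatter), and adding pentyl does not have one size along the chain: the same change on two cores in this assay, a 1.3-fold lower number (0.10 log units; within the scatter) from compound 2 to compound 3 and a 56-fold higher number (1.74 log units; beyond the scatter) from compound 4 to compound 1, 70-fold (1.85 log units) apart, beyond the scatter of two such steps Removing or adding ethyl likewise depends on the chain that carries it, so the large penalty in this set belongs to compound 1 alone: the same change on two cores in this assay, a 33-fold lower number (1.52 log units; beyond the scatter) from compound 1 to compound 3 and a 2.1-fold higher number (0.32 log units; beyond the scatter) from compound 4 to compound 2, 70-fold (1.85 log units) apart, beyond the scatter of two such steps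

The compounds shown leave open where the number starts to climb as the chain grows from that of compound 3 to that of compound 1, and whether a chain shorter than that of compound 2 keeps the number low. They also leave open how a branched chain, or a chain carrying an amine or a carboxylic acid, would read in this assay.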